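Acetyl on the ring amine of compound 1

A few compounds are considered here, and "the series" means these few. Any claim that something is new, unique, unknown or untested is made for them only; others in the source may bear on it.

- compound 1 `Cc1c2c(n3c1CCCNC[C@H](C)Nc1cc-3ccc1C(N)=O)CC(C)(C)CC2=O`: > 100 ug/mL (a limit)
- compound 2 `COCCN1CC[C@H](C)Nc2cc(ccc2C(N)=O)-n2c(c(C)c3c2CC(C)(C)CC3=O)CC1=O`: > 100 ug/mL (a limit)

In a physicochemical assay for solubility (on this read-out lower numbers stand for lower solubility and higher numbers for higher solubility), compound 1 gives > 100 ug/mL as a limit and not a number. Compound 2 gives > 100 ug/mL as a limit too. Compound 1 thus stands at the limit of > 100 ug/mL in this assay, at which 2 of the 2 values shown sit, with no exact number of its own. For the measured compounds named here, compound 3 `CC(=O)N1CCCc2c(C)c3c(n2-c2ccc(C(N)=O)c(c2)N[C@@H](C)C1)CC(C)(C)CC3=O` has acetyl in place of hydrogen on an amine nitrogen in a ring as its one change. Going by the values given here, no measured step covers this change, so a moderate downward step in this assay is expected, and another limit reading remains possible. The estimated change is an at least 1.2-fold lower number from compound 1 to compound 3 (0.09 log units; that floor lies within the scatter) as a rough figure. For compound 3 the expected value is 80 ug/mL with an estimated range of 25 ug/mL to 150 ug/mL for now.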

Compound 3, solubility: 69 ug/mL
The estimate for compound 3 lay 1.2-fold (0.06 log units) above the measured number; the measured number falls inside the stated range.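

With acetyl in place of hydrogen on this amine nitrogen in a ring, the series gains a reading with an exact number in this assay: compound 3 gives 69 ug/mL. The change amounts to an at least 1.4-fold lower number from compound 1 to compound 3 (0.16 log units; that floor lies within the scatter), which is a floor and sets no upper size for the step. The other compounds stay at a limit: the limit of > 100 ug/mL in this assay, at which 2 of the 3 values shown sit.

As far as these compounds go, the full size of the step stays open, as the reading for compound 1 is only a limit. Also open, from the compounds shown here alone, is how a longer acyl chain or a carboxylic acid on this nitrogen would read.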